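Removing a Chain Methyl From Compound 2

This account rests on a few compounds, and the source may have more. Where it says the series, first, only, none or still open, it means among the compounds named here.

Measured compounds:
compound 1 `C=CC[C@H]1C[C@]2([C@@H](C)Cc3ccc(OC)c(OC)c3)OCOC2=CC1=O` 110 nM
compound 2 `C=CC[C@H]1C[C@]2([C@H](C)Cc3ccc(OC)c(OC)c3)OCOC2=CC1=O` 300 nM
compound 3 `C=CC[C@@H]1C[C@]2([C@H](C)Cc3ccc(OC)c(OC)c3)OCOC2=CC1=O` > 4000 nM

In a functional assay on M14 cells (Homo sapiens) for antiproliferative activity, with a stated time of 72 h (on this read-out higher numbers stand for weaker inhibition and lower numbers for stronger inhibition), compound 1 gives 110 nM and compound 2 gives 300 nM. For compound 3 the assay reports only a limit, > 4000 nM. Compound 2 holds the highest of the two numbers shown; the step of a 2.7-fold higher number from compound 1 to compound 2 (0.44 log units; beyond the scatter) is beyond the scatter, which rests on (the fact that compounds 1 and 2 differ only in the configuration as drawn). Compound 4 `C=CC[C@H]1C[C@]2(CCc3ccc(OC)c(OC)c3)OCOC2=CC1=O` differs from compound 2 by hydrogen in place of methyl on a saturated chain carbon bound to a saturated chain carbon and a saturated ring carbon, hydrogen in place of methyl on a saturated chain carbon. Among the measured compounds shown here, none of the measured steps, a 2.7-fold higher number from compound 1 to compound 2 (0.44 log units; beyond the scatter), an at least 36-fold higher number from compound 1 to compound 3 (1.56 log units; beyond the scatter) or an at least 13-fold higher number from compound 2 to compound 3 (1.12 log units; beyond the scatter), swaps a group; each changes configuration alone. The step of no change at the digits printed from compound 2 to compound 4 (within the scatter) is therefore expected to stay modest, with no firm direction. Compound 4 is estimated at 300 nM, between 100 nM and 1200 nM.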

Compound 4, half-maximal inhibitory concentration: 2000 nM
For compound 4 the middle estimate is 6.7-fold (0.82 log units) below the measured one; measured number outside the range, above it.
By their numbers in this assay, from the lowest: compound 1; then compound 2; then compound 4. At a limit, above all of these: compound 3.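

Among the compounds shown here, removing the methyl itself brings a 6.7-fold higher number from compound 2 to compound 4 (0.82 log units; beyond the scatter) and an 18-fold higher number from compound 1 to compound 4 (1.26 log units; beyond the scatter) in this assay at a place where the earlier compounds only changed its configuration. Compounds 1 and 2 both give lower numbers than compound 4, so on this saturated chain carbon the methyl goes with stronger inhibition whichever way it is drawn. Nothing measured here explains why the methyl counts.

From the compounds shown here alone, whether an ethyl group, a hydroxyl group or a fluorine atom on this carbon would match the methyl stays open.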